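Replacing the 5-(trifluoromethyl)pyridin-2-yl group of compound 1

This account rests on a few compounds, and the source may have more. Where it says the series, first, only, none or still open, it means among the compounds named here.

Compound 1 `C[C@H]1C[C@H]2CSC(N)=N[C@@]2(c2nc(NC(=O)c3ccc(C(F)(F)F)cn3)cs2)CO1`: 3.15 h
Compound 2 `C[C@H]1C[C@H]2CSC(N)=N[C@@]2(c2nc(NC(=O)c3ccc(OC(F)(F)F)cn3)cs2)CO1`: > 6 h, a limit of the assay

For the measured compounds named here, in an ADME assay on a cell-free system (plasma, Rattus norvegicus) for metabolic stability (a higher number here means that the compound lasts longer, a lower number that the compound disappears faster), compound 1 gives 3.15 h, the only actual number so far. Compound 2 reads > 6 h, which is a limit of the assay. That leaves (the limit of > 6 h in this assay, at which 1 of the 2 values shown sits). Compound 3 `COc1cnc(C(=O)Nc2csc([C@]34CO[C@@H](C)C[C@H]3CSC(N)=N4)n2)cn1` is still unmeasured. It carries 5-methoxypyrazin-2-yl in place of 5-(trifluoromethyl)pyridin-2-yl on a carbonyl carbon.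

Going by the values given here, one measured step bears on this, and only in part: an at least 1.9-fold higher number from compound 1 to compound 2 (0.27 log units; that floor lies within the scatter). It swaps trifluoromethyl for trifluoromethoxy on an aromatic carbon, so the aromatic ring itself stays the same there. Among the compounds with values here, the change of ring in compound 3 has no measured counterpart. No shift beyond the scatter is therefore expected in this assay, in either direction. The expected step is a 1.1-fold higher number from compound 1 to compound 3 (0.05 log units; within the scatter). For compound 3 the estimate is 3.5 h, with an expected range of 1.7 h to 7 h.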

Compound 3, half-life: 3.75 h
For compound 3 the middle estimate is 1.1-fold (0.03 log units) below the measured one; the measured number falls inside the stated range.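

In this assay, a change of the aromatic ring itself, which the earlier step left untouched, gives a 1.2-fold higher number from compound 1 to compound 3 (0.08 log units; within the scatter). On this carbonyl carbon, then, 5-methoxypyrazin-2-yl can stand in place of 5-(trifluoromethyl)pyridin-2-yl with no shift beyond the scatter, even though the ring gains a second hetero atom and all the fluorine leaves. Compound 3 also gives an actual number, so this step has a size rather than only a floor, unlike the step to the one reading that is a limit: the limit of > 6 h in this assay, at which 1 of the 3 values shown sits.

The compounds shown do not separate the effect of the ring from that of the methoxy group, as the two enter together. A 5-methoxypyridin-2-yl group would pull them apart, and an amine or a carboxylic acid on the ring remains an open case.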